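Exchanging One Aryl Group for Another on a Shared Core

This account rests on a few compounds, and the source may have more. Where it says the series, first, only, none or still open, it means among the compounds named here.

Compound 1 `Nc1cc(N)c2nc(-c3ccccc3)c(Oc3ccc(Cl)c(Cl)c3)nc2c1`; compound 2 `COc1ccc(CNc2nc3cc(N)cc(N)c3nc2-c2ccccc2)cc1OC`.

In a functional assay on OVCAR-4 cells (Homo sapiens) for inhibition, read by sulforhodamine B assay, with a stated time of 48 h (a higher number here means a weaker inhibitor of growth, a lower number a stronger inhibitor of growth), compound 1 gives only a limit of the assay, < 100000 nM, not a number. In this assay, going by the values given here, compound 2 gives 7410 nM, the single actual number in this set. Among the compounds with values here, the evidence on the measured values is the limit of < 100000 nM in this assay, at which 1 of the 2 values shown sits, so compound 2 stands alone as the only compound with a numerical result. Compound 3 `Nc1cc(N)c2nc(-c3ccccc3)c(NCc3ccc(F)cc3)nc2c1` differs from compound 2 in one place: 4-fluorophenyl in place of 3,4-dimethoxyphenyl on a saturated chain carbon bound to a nitrogen on an aromatic ring. No step between two measured compounds is available to gauge a change of this kind, so its size cannot be read from what is shown. The expectation is a shift within the usual scatter, with no clear direction, and compound 3 is estimated at 9000 nM with a range from 3000 nM to 30000 nM. The expected step of a 1.2-fold higher number from compound 2 to compound 3 (0.08 log units; within the scatter) is accordingly small.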

Compound 3, concentration for total growth inhibition: 8130 nM
Compound 3: the middle estimate sits 1.1-fold (0.04 log units) above what was measured; low and high end bracket the measured number.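

Going by these compounds alone, putting 4-fluorophenyl in place of 3,4-dimethoxyphenyl on a saturated chain carbon bound to a nitrogen on an aromatic ring gives a 1.1-fold higher number from compound 2 to compound 3 (0.04 log units; within the scatter), the first step at this position that can be read. In this assay, this pair therefore cannot be told apart, even though the group that enters and the group that leaves differ in their counts of heavy atoms and hydrogen-bond acceptors. The other step, with (4-fluorobenzyl)amino in place of 3,4-dichlorophenoxy, cannot be read because compound 1 gives only a limit: the limit of < 100000 nM in this assay, at which 1 of the 3 values shown sits.

On these data alone, a single pair says little about this position as a whole, so it remains open whether a plain phenyl ring, or one carrying an amine or a carboxylic acid, would behave the same way. As far as these compounds go, the effect of a longer chain carrying the ring also remains open.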